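The source may report more compounds than this note shows. Statements on the series, on what has been measured and on what is new or still open speak of the compounds shown alone.

Measured compounds:
- Compound 1 `O=C(Nc1ccc(NCc2ccc(Cl)cc2)cc1Cl)c1cc(Cl)ccc1O`: 59700 nM
- Compound 2 `O=C(Nc1ccc(NCc2cc(Cl)cc(Cl)c2)cc1Cl)c1cc(Cl)ccc1O`: 13300 nM
- Compound 3 `O=C(Nc1ccc(NCc2cccnc2Cl)cc1Cl)c1cc(Cl)ccc1O`: 101000 nM

All three were tested in an ADME assay on A549 cells (Homo sapiens) for cytotoxicity, read by resazurin assay, with a stated time of 48 h; on this read-out lower numbers stand for higher toxicity in this test and higher numbers for lower toxicity in this test. Compound 3, at 101000 nM, stands level with compound 1, since a 1.7-fold higher number from compound 1 to compound 3 (0.23 log units; within the scatter) does not separate them. Compound 2 stands apart, with a 4.5-fold lower number from compound 1 to compound 2 (0.65 log units; beyond the scatter) and a 7.6-fold higher number from compound 2 to compound 3 (0.88 log units; beyond the scatter).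

Compound 4 `CC(CCO)Nc1ccc(NC(=O)c2cc(Cl)ccc2O)c(Cl)c1` awaits its reading. Its change is 3-hydroxy-1-methylpropyl in place of (2-chloropyridin-3-yl)methyl on a nitrogen on an aromatic ring. For the measured compounds named here, no measured step removes the ring from this group, since each only exchanges one ring-bearing group for another, so they bear on the change only loosely. Going by the values given here, only the steps involving compound 2 left the scatter, and both were modest. No shift beyond the scatter is therefore expected, and no direction can be claimed with confidence. The expected change is a 1.4-fold lower number from compound 3 to compound 4 (0.16 log units; within the scatter). The estimated value for compound 4 is 70000 nM, with an expected range of 22000 nM to 200000 nM.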

Compound 4, half-maximal cytotoxic concentration: 200000 nM
The estimate for compound 4 lay 2.9-fold (0.46 log units) below the measured number; the range from low to high includes it.
By their numbers in this assay, from the lowest: compound 2; then compounds 1, 3 and 4 (each within the scatter of the next, the first and the last beyond it).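

A group with no ring at this place, 3-hydroxy-1-methylpropyl on the nitrogen, reads level with (2-chloropyridin-3-yl)methyl in this assay, as a 2.0-fold higher number from compound 3 to compound 4 (0.30 log units; within the scatter) shows, so a ring in this group is not required for a high number here. The same group stands clear of both benzyl groups, with a 3.4-fold higher number from compound 1 to compound 4 (0.53 log units; beyond the scatter) against 4-chlorobenzyl and a 15-fold higher number from compound 2 to compound 4 (1.18 log units; beyond the scatter) against 3,5-dichlorobenzyl, the largest step among these compounds. Nothing available here explains why these steps take the size they do.

For the compounds shown here, with only one ringless group present, the compounds do not separate the part played by its hydroxyl from that of its branching methyl. On these data alone, how a plain butyl chain, a longer chain, or an amine or carboxylic acid in place of the hydroxyl would read in this assay remains open.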